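Losing the 4-Chlorobenzyl Group: What Compound 3 May Show

This account rests on a few compounds, and the source may have more. Where it says the series, first, only, none or still open, it means among the compounds named here.

Compound 1 `O=C(NCc1ccccc1)c1csc(-c2c[nH]c3ccccc23)n1`: > 100000 nM
Compound 2 `O=C(Nc1ccccc1)c1csc(-c2cn(Cc3ccc(Cl)cc3)c3ccccc23)n1`: 50500 nM

Of the compounds shown here, two have so far been tested in a functional assay on MDA-MB-231 cells (Homo sapiens) for cytotoxicity, read by MTT assay, with a stated time of 48 h, in the absence of a further agent; on this read-out lower numbers stand for stronger inhibition and higher numbers for weaker inhibition. Compound 1 reaches only the limit of the assay, > 100000 nM, which is not a true number. For the measured compounds named here, compound 2 gives 50500 nM, the single real number in this small set. Compound 1 is the one that sits at the limit of > 100000 nM in this assay, at which 1 of the 2 values shown sits.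

Compound 3 `O=C(Nc1ccccc1)c1csc(-c2c[nH]c3ccccc23)n1` has not been measured. It differs from compound 2 in one place: hydrogen in place of 4-chlorobenzyl on an aromatic nitrogen. Going by the values given here, no measured pair shows this exact step. Compound 1, which also carries hydrogen on that nitrogen, sits at > 100000 nM. On that basis the step from compound 2 to compound 3 is expected to be a 2.6-fold higher number from compound 2 to compound 3 (0.41 log units; beyond the scatter), a loss beyond the usual scatter. Compound 3 is therefore estimated near 130000 nM, between 40000 nM and 400000 nM, with a real chance that only a limit is reported.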

Compound 3, half-maximal inhibitory concentration: 79400 nM
For compound 3 the middle estimate is 1.6-fold (0.21 log units) above the measured one; the measured number falls inside the stated range.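

In this assay, for the compounds shown here, taking the 4-chlorobenzyl group off the aromatic nitrogen gives a 1.6-fold higher number from compound 2 to compound 3 (0.20 log units; within the scatter), so this change of 8 heavy atoms to a single hydrogen leaves compounds with no real difference in this test, something no earlier pair could show. On the amide-type nitrogen, phenyl in place of benzyl gives an at least 1.2-fold lower number from compound 1 to compound 3 (0.10 log units; that floor lies within the scatter), so no real difference between these two groups can be claimed. That step is only a floor, since compound 1 stands at a limit of the assay and not at a number: the limit of > 100000 nM in this assay, at which 1 of the 3 values shown sits.

Still open, going by these compounds, is whether another group on that aromatic nitrogen, such as methyl or a longer chain ending in an amine, would move the number beyond the scatter. The same question stands for a carboxylic acid on the phenyl of the amide.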